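Replacing the formyl group of a potent antiproliferative compound

The compounds below may be only part of what the source reports. "The series", "measured", "known", "first", "only" and "open" are said of these compounds alone.

For the measured compounds named here, in a functional assay on MDA-MB-231 cells (Homo sapiens) for antiproliferative activity, with a stated time of 4 days (a lower number here means a stronger inhibitor, a higher number a weaker inhibitor), compound 1 `CCCCc1ccc2[nH]c(-c3ccc(OC)cc3)c(C=O)c2c1` gives 6.7 nM, the lower of the two numbers measured so far. Going by the values given here, the only other measured compound, compound 2 `CCCCc1ccc2[nH]c(-c3ccc(C(F)(F)F)cc3)c(C=O)c2c1`, gives 33 nM. Compound 3 `CCCCc1ccc2[nH]c(-c3ccc(OC)cc3)c(/C=N/O)c2c1` keeps the core of compound 1 and alters a single group: a group of 3 heavy atoms (1 carbon, 1 nitrogen, 1 oxygen; no ring) in place of a group of 2 heavy atoms (1 carbon, 1 oxygen; no ring), on an aromatic carbon. The formyl on an aromatic carbon gives way to a group of 3 heavy atoms at the same place.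

Among the compounds with values here, only one measured step is available, a 4.9-fold higher number from compound 1 to compound 2 (0.69 log units; beyond the scatter). It lies beyond the scatter, but it replaces methoxy with trifluoromethyl elsewhere in the molecule, so it bears on the new change only indirectly. It gives a rough idea of how far one substitution can move the number in this assay. Within the data shown here, no measurement yet shows what a change at the formyl does. Among the measured compounds shown here, compound 1 holds the lowest number so far, at 6.7 nM, so a modest rise seems the likelier outcome, although no change beyond the scatter remains possible. The expected step is a 3.3-fold higher number from compound 1 to compound 3 (0.52 log units; beyond the scatter). For compound 3 the estimated value is 22 nM, with an expected range of 6 nM to 90 nM.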

Compound 3, half-maximal inhibitory concentration: 40 nM
Beside the measured number, compound 3's estimate is 1.8-fold (0.26 log units) below it, and the stated range covers the measured number.
By their numbers in this assay, from the lowest: compound 1; then compounds 2 and 3 (each within the scatter of the next).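

In this assay, the formyl position proves sensitive to change: swapping the formyl for the group of 3 heavy atoms gives a 6.0-fold higher number from compound 1 to compound 3 (0.78 log units; beyond the scatter). For the compounds shown here, this is the first direct measurement at this position, since the earlier step changed only the substituent on the outer aromatic ring, and it shows that the formyl can be replaced without losing activity altogether, as compound 3 still gives 40 nM, though at a real cost in potency. The entering group differs from the formyl by one more heavy atom, a nitrogen, and by one more hydrogen-bond donor and one more acceptor, but no measurement here links the rise in the number to any one of these differences.

Going by these compounds, with only one replacement at this position, it remains open whether the rise applies to replacements of the formyl generally or to this group alone, and a nitrile, a carboxylic acid or a hydroxymethyl group at the same place would help to separate the two. On these data alone, it is also open whether the same replacement would cost as much on the core of compound 2, which carries trifluoromethyl instead of methoxy.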